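This account rests on a few compounds, and the source may have more. Where it says the series, first, only, none or still open, it means among the compounds named here.

The piece follows the step from compound 2 `Cc1nc(C)c(Cn2ncc3c(Nc4ccc(OC(F)(F)F)cc4)ncnc32)s1` to compound 4 `CC(C)(C)n1ncc2c(Nc3ccc(OC(F)(F)F)cc3)ncnc21`, which has yet to be measured in an ADME assay on BaF3 cells (Mus musculus) for cytotoxicity; on this read-out higher numbers stand for an effect only at larger amounts of compound and lower numbers for an effect already at smaller amounts. Compound 2 stands at a limit of the assay: in this assay compound 2 gives > 10000 nM. Its two companions share that standing. Compound 1 `NC(=O)c1ccc(Cn2ncc3c(Nc4ccc(OC(F)(F)F)cc4)ncnc32)cc1` also sits at a limit, giving > 10000 nM in this assay. Compound 3 `NS(=O)(=O)c1cccc(-c2cc(Nc3ccc(OC(F)(F)F)cc3)ncn2)c1` likewise reaches only a limit, with > 10000 nM in this assay. For the measured compounds named here, the one step joining measured compounds, a step that the two limits leave unreadable from compound 1 to compound 2, runs between two limits and its size cannot be read. The change to compound 4 is tert-butyl in place of (2,4-dimethyl-1,3-thiazol-5-yl)methyl on an aromatic nitrogen. No measured step bears on it with a readable size; the only guidance is the limit of > 10000 nM in this assay, at which 3 of the 3 values shown sit, so no direction beyond the scatter can be drawn from the numbers shown. Compound 4 is therefore expected to give 20000 nM, most likely reported again as a limit, within a range from 5000 nM to 100000 nM. The step that the limit leaves unreadable from compound 2 to compound 4 is accordingly estimated to be none beyond the scatter.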

Compound 4, half-maximal effective concentration: 7300 nM
The estimate for compound 4 lay 2.7-fold (0.44 log units) above the measured number; measured number inside the range.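

In this assay compound 4 gives 7300 nM, the first value shown that is a number and not a limit, so a group on this aromatic nitrogen can bring the read-out into the measurable range. Tert-butyl in place of (2,4-dimethyl-1,3-thiazol-5-yl)methyl gives an at least 1.3-fold lower number from compound 2 to compound 4 (0.13 log units; that floor lies within the scatter), and tert-butyl in place of 4-carbamoylbenzyl gives an at least 1.3-fold lower number from compound 1 to compound 4 (0.13 log units; that floor lies within the scatter); both are floors only, so neither step is shown to exceed the scatter. The other compounds offer no second number to set beside compound 4: the limit of > 10000 nM in this assay, at which 3 of the 4 values shown sit.

From the compounds shown here alone, how far compound 1 and compound 2 really lie past their limits stays open, and with it the true size of both steps. Also open, going by these compounds, is whether a shorter chain such as an ethyl group, or a cyclohexyl ring, on the same nitrogen would give a number in this range.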